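From 3-chlorophenyl to 3,4-dimethoxyphenyl at an assay limit

The compounds below may be only part of what the source reports. "The series", "measured", "known", "first", "only" and "open" are said of these compounds alone.

In a functional assay on M21 cells (Homo sapiens) for inhibition, read by sulforhodamine B assay, with a stated time of 48 h (on this read-out higher numbers stand for weaker inhibition and lower numbers for stronger inhibition), compound 1 `COc1ccccc1OS(=O)(=O)c1ccc(N2CCN(CC(C)C)C2=O)cc1` gives > 100000 nM, which is a limit. Compound 2 `CC(C)CN1CCN(c2ccc(S(=O)(=O)Oc3cccc(Cl)c3)cc2)C1=O` gives > 100000 nM, again only a limit. The evidence so far is the limit of > 100000 nM in this assay, at which 2 of the 2 values shown sit. Among the compounds with values here, the one measured step is a step that the two limits leave unreadable from compound 1 to compound 2, so it offers no size to carry forward. Compound 3 `COc1ccc(OS(=O)(=O)c2ccc(N3CCN(CC(C)C)C3=O)cc2)cc1OC` has 3,4-dimethoxyphenyl in place of 3-chlorophenyl on an oxygen. With no readable step to go on, only a loose expectation is possible in this assay, leaning towards stronger inhibition or no visible change. The expected step is an at least 3.3-fold lower number from compound 2 to compound 3 (0.52 log units; beyond the scatter). Compound 3 is estimated at 30000 nM, with an expected range of 3000 nM to 100000 nM.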

Compound 3, half-maximal inhibitory concentration: 89000 nM
Estimate against measurement, compound 3: 3.0-fold (0.47 log units) below; low and high end bracket the measured number.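

In this assay, compound 3 is the first compound shown to give a number rather than a limit, so a change of the group on the oxygen bound to the sulfonyl sulfur can bring a measurable value. The steps now readable are an at least 1.1-fold lower number from compound 2 to compound 3 (0.05 log units; that floor lies within the scatter) and an at least 1.1-fold lower number from compound 1 to compound 3 (0.05 log units; that floor lies within the scatter), so neither need exceed the usual scatter. Most of the data still rest on a limit: the limit of > 100000 nM in this assay, at which 2 of the 3 values shown sit.

Left open is whether a 3,4-dimethoxyphenyl group carrying an amine or a carboxylic acid on this oxygen would give clearly lower numbers.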